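The compounds below may be only part of what the source reports. "The series", "measured", "known", "first", "only" and "open" are said of these compounds alone.

Compound 1 `Cc1cccc(NC(=O)c2nn(C)c(-c3ccccc3)c2C)n1`: 0.567 h
Compound 2 `Cc1cccc(NC(=O)c2nn(C)c(-c3ccc(F)cc3)c2C)n1`: 0.933 h
Compound 3 `Cc1cccc(NC(=O)c2nn(C)c(-c3cc(F)cc(F)c3)c2C)n1`: 1.07 h

All three compounds were measured in an ADME assay on microsomes from liver (Rattus norvegicus) for metabolic stability; on this read-out lower numbers stand for a shorter-lived compound and higher numbers for a longer-lived compound. Compound 2 stands at 0.933 h, and its number cannot be told apart from the other two, since both of its measured steps lie within the scatter.

The next compound, compound 4 `Cc1cccc(NC(=O)c2nn(C)c(-c3ccc(C(F)(F)F)cc3)c2C)n1`, has not yet been measured. It differs from compound 2 by one change: trifluoromethyl in place of fluoro on an aromatic carbon. In words, this is trifluoromethyl in place of fluoro on an aromatic carbon, para to a large group. Among the compounds with values here, no measured step makes this exchange, so the evidence is indirect.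

The closest step is a 1.6-fold higher number from compound 1 to compound 2 (0.22 log units; within the scatter), which brought in the fluoro that now leaves. The other two change the fluorine pattern on the same aromatic ring: a 1.9-fold higher number from compound 1 to compound 3 (0.28 log units; within the scatter) and a 1.1-fold higher number from compound 2 to compound 3 (0.06 log units; within the scatter). None of the three moved the number beyond the scatter, although three compounds are a narrow basis.

Going by a 1.6-fold higher number from compound 1 to compound 2 (0.22 log units; within the scatter) and a 1.1-fold higher number from compound 2 to compound 3 (0.06 log units; within the scatter), no step beyond the scatter is expected in this assay, and neither direction is favoured. The expected step is a 1.1-fold higher number from compound 2 to compound 4 (0.03 log units; within the scatter). For compound 4 the estimated half-life is 1 h, with an expected range from 0.5 h to 2 h.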

Compound 4, half-life: > 5 h
Compound 4: no number, only a limit (the forecaster's own chance of this, stated with the estimate: 3%); middle value at least 5.0-fold (0.69 log units) away from the limit.
By their numbers in this assay, from the lowest: compounds 1, 2 and 3 (each within the scatter of the next). At a limit, above all of these: compound 4.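

In this assay, within the data shown here, the place para to a large group turns out to respond to what stands there: trifluoromethyl in place of fluoro gives an at least 5.3-fold higher number from compound 2 to compound 4 (0.72 log units; beyond the scatter), the first step to lie beyond the scatter, while all the steps among the earlier compounds stayed within it. Set against the unsubstituted phenyl of the core, trifluoromethyl gives an at least 8.8-fold higher number from compound 1 to compound 4 (0.94 log units; beyond the scatter), whereas fluoro at the same place gave a 1.6-fold higher number from compound 1 to compound 2 (0.22 log units; within the scatter), so in this small set the two groups do not read alike at this place. Compound 4 carries only a limit and not a number, so both of its steps give a lowest size and no true size: the limit of > 5 h in this assay, at which 1 of the 4 values shown sits.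

The compounds shown leave open how long-lived compound 4 actually is, and which feature of the trifluoromethyl group goes with its step, since a single exchange cannot separate them. They also leave open whether a chloro, a methyl, a methoxy or a nitrile at this place would give a step of the same kind, and whether trifluoromethyl would do so elsewhere on the ring.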